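The compounds below may be only part of what the source reports. "The series", "measured", "known", "first", "only" and "open" are said of these compounds alone.

Working notes on the series

Compound 1 `COC(=O)[C@@]1(C)CCC=C2[C@@H]1CC[C@@H](C)[C@]2(C)Cc1c[nH]c2ccc(F)cc12` gives 4800 nM in a functional assay on HBL-100 cells (Homo sapiens) for inhibition, read by sulforhodamine B assay, with a stated time of 48 h; on this read-out lower numbers stand for stronger inhibition of growth and higher numbers for weaker inhibition of growth. Compound 3 `COC(=O)[C@@]1(C)CCC=C2[C@@H]1CC[C@@H](C)[C@]2(C)Cc1c(C)[nH]c2ccc(F)cc12` carries the change methyl in place of hydrogen on an aromatic carbon relative to compound 1; in this assay compound 3 gives 14000 nM, and the step is a 2.9-fold higher number from compound 1 to compound 3 (0.46 log units; beyond the scatter). Compound 2 `COC(=O)[C@@]1(C)CCC=C2[C@@H]1CC[C@@H](C)[C@]2(C)Cc1c(C)[nH]c2ccccc12` gives 14000 nM in this assay; how its core differs from that of compound 1 is not broken down here. Between compound 2 and compound 3 the step is no change at the digits printed from compound 2 to compound 3 (within the scatter), so the two sit together at the high end of the three numbers.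

Compound 4 `COC(=O)[C@@]1(C)CCC=C2[C@@H]1CC[C@@H](C)[C@]2(C)Cc1c(C)[nH]c2c(C)cccc12` is not yet measured. Relative to compound 2 it carries methyl in place of hydrogen on an aromatic carbon. Going by the values given here, this is the same kind of change as the one from compound 1 to compound 3, but the place differs: there the methyl entered on a five-membered aromatic ring with one nitrogen, next to the ring nitrogen and next to the ring atom that bears a large group; here it enters on a six-membered aromatic ring of carbon only, ortho to a fused ring and meta to a fused ring. Among the compounds with values here, because the only measured methyl step, a 2.9-fold higher number from compound 1 to compound 3 (0.46 log units; beyond the scatter), weakened inhibition modestly, a step of similar direction and size, a 1.6-fold higher number from compound 2 to compound 4 (0.20 log units; within the scatter), is expected from compound 2 to compound 4, with the caveat that the different place gives no direct precedent. Compound 4 is therefore estimated at 22000 nM in this assay, expected to fall between 8000 nM and 60000 nM.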

Compound 4, concentration for 50% growth inhibition: 16000 nM
Compound 4: the middle estimate sits 1.4-fold (0.14 log units) above what was measured, and the stated range covers the measured number.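

In this assay the added methyl gives a 1.1-fold higher number from compound 2 to compound 4 (0.06 log units; within the scatter), so on the core of compound 2 this change leaves the number where it was. Set beside the earlier methyl step, the result cannot be told apart from it: the same change on two cores in this assay, a 2.9-fold higher number (0.46 log units; beyond the scatter) from compound 1 to compound 3 and a 1.1-fold higher number (0.06 log units; within the scatter) from compound 2 to compound 4, 2.6-fold (0.41 log units) apart, within the scatter of two such steps. Going by these compounds alone, this does not show that the change carries over intact from one core to the other: only two pairs are at hand, the methyl stands in a different place in each, here on a six-membered aromatic ring of carbon only, ortho to a fused ring, and the data do not separate place from core.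

Still open, from the compounds shown here alone, is whether a methyl at this place would give the same result on the core of compound 1, and whether any group other than methyl or fluoro on the aromatic carbons moves the number in either direction. A chloro group, a methoxy group or a longer chain such as ethyl at these places would address this, as would a carboxylic acid in place of the ester.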